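Anilide para-substituent swap in a cyclopropane dicarboxamide series

A few compounds are considered here, and "the series" means these few. Any claim that something is new, unique, unknown or untested is made for them only; others in the source may bear on it.

Measured so far:
compound 1, `CN(C)C(=O)c1cc2cnc(Nc3ccc(NC(=O)C4(C(=O)Nc5ccc(F)cc5)CC4)cc3F)nc2n1C1CCCC1`, gives 44.4% in a functional assay on SiHa cells (Homo sapiens) for inhibition, read by CCK-8 assay, with a stated time of 72 h, tested at 10 uM; a lower number here means less inhibition of growth, a higher number more inhibition of growth at the concentration tested
compound 2, `CN(C)C(=O)c1cc2cnc(Nc3ccc(NC(=O)C4(C(=O)Nc5ccc(Br)cc5)CC4)cc3)nc2n1C1CCCC1`, gives 98.8% in this assay

Going by the values given here, compound 2 holds the highest of the two numbers in this assay; its only neighbour, compound 1, sits lower by a gap beyond the usual scatter. Compound 3, `Cc1ccc(NC(=O)C2(C(=O)Nc3ccc(Nc4ncc5cc(C(=O)N(C)C)n(C6CCCC6)c5n4)cc3)CC2)cc1`, has not yet been measured. Relative to compound 2 it carries methyl in place of bromo on an aromatic carbon. Among the compounds with values here, no step between measured compounds isolates this change, so no direct precedent exists. The expected step of a number 10.8 percentage points lower from compound 2 to compound 3 (beyond the scatter) is a modest drop, possibly within the scatter. For compound 3 the estimate in this assay is 88%, within 60% to 100%.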

Compound 3, percent growth inhibition at one concentration: 104%
For compound 3 the middle estimate is 16 percentage points below the measured one, and the stated range ends below it.
By their numbers in this assay, from the lowest: compound 1; then compounds 2 and 3 (each within the scatter of the next).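

In this assay, going by these compounds alone, the change from 4-bromophenyl to 4-methylphenyl gives a number 5.2 percentage points higher from compound 2 to compound 3 (within the scatter), so at this aromatic carbon a methyl serves as well as a bromo, and this is the only single-place step. Compound 1 differs from compound 2 and compound 3 in more than one place, so its lower value cannot be assigned to this position. No measured evidence on the origin of this result is available. From the compounds shown here alone, what a methoxy group, an amine or a carboxylic acid on this carbon would give remains open.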